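The source may hold more compounds than are shown below. What is called first, only, known or untested is meant among the compounds shown, and "the series" means these compounds.

Compound 2, with the structure `CCC(C)(C)Cc1c[nH]c(CCc2ccc(-c3ccc(F)cn3)cc2)n1`, holds the lowest of the two numbers measured in an in vitro assay on CHO cells for displacement of a labelled ligand from Bombesin receptor subtype-3 (Homo sapiens), read by scintillation counting, with a stated time of 2 h; a lower number here means a stronger inhibitor, a higher number a weaker inhibitor. In this assay, among the compounds with values here, compound 2 gives 19 nM, while its only neighbour, compound 1 with the structure `CCC(C)(C)Cc1c[nH]c(CCc2ccc(-n3ccnn3)cc2)n1`, gives 390 nM. Within the data shown here, the one measured step, a 21-fold lower number from compound 1 to compound 2 (1.31 log units; beyond the scatter), shows that the group on the para position of the phenyl ring is a place where a change can move the number a long way.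

Compound 3, with the structure `CCC(C)(C)Cc1c[nH]c(CCc2ccc(N3CCCCC3)cc2)n1`, has not yet been measured in this assay. It differs from compound 2 in one place: piperidin-1-yl in place of 5-fluoropyridin-2-yl on an aromatic carbon.

Among the measured compounds shown here, no measured step tests a non-aromatic ring at this place, so the direction is uncertain. For the measured compounds named here, the single step of a 21-fold lower number from compound 1 to compound 2 (1.31 log units; beyond the scatter) only shows that swapping one ring for another here can change the number greatly. Since the gain in compound 2 came with the 5-fluoropyridin-2-yl group that is now removed, a weaker result is expected for compound 3, with the estimated step of a 5.3-fold higher number from compound 2 to compound 3 (0.72 log units; beyond the scatter). The estimate for compound 3 in this assay is 100 nM, with a range from 25 nM to 400 nM.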

Compound 3, half-maximal inhibitory concentration: 28 nM
For compound 3 the middle estimate is 3.6-fold (0.55 log units) above the measured one; measured number inside the range.
By their numbers in this assay, from the lowest: compounds 2 and 3 (each within the scatter of the next); then compound 1.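

Aromatic character is not needed at this place to reach a low number: with a 1.5-fold higher number from compound 2 to compound 3 (0.17 log units; within the scatter) in this assay, the non-aromatic piperidin-1-yl ring cannot be told apart from the aromatic 5-fluoropyridin-2-yl ring. The earlier step showed only that one aromatic group was far better than another; now a 14-fold lower number from compound 1 to compound 3 (1.14 log units; beyond the scatter) shows that the 1H-1,2,3-triazol-1-yl group of compound 1 is also well beaten by a non-aromatic ring, so compound 1 is the one that stands apart among these three. An aromatic ring alone therefore does not sort these compounds, since compound 1 carries one and still gives the highest number. Nothing available explains why the two six-membered rings give such similar results or why compound 1 differs.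

The compounds shown leave open whether a ring is needed here at all, which an open-chain amine such as diethylamino or a short chain such as butyl would help to test. They also leave open how much the piperidin-1-yl ring itself can be altered, for example by replacing one of its carbons with oxygen to give morpholin-4-yl.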